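The compounds below may be only part of what the source reports. "The series", "measured", "known", "first", "only" and "open" are said of these compounds alone.

Measured compounds in a functional assay on the whole organism with Mus musculus as the target; on this read-out higher numbers stand for an effect only at larger amounts of compound and lower numbers for an effect already at smaller amounts:
- compound 1 `C[C@@H](NCc1ccc(OCc2ccccc2)cc1)C(N)=O` gives 23.8 mg/kg
- compound 2 `CNC(=O)[C@H](NCc1ccc(OCc2ccccc2)cc1)C(C)C` gives 112 mg/kg
- compound 3 `CC[C@@H](NCc1ccc(OCc2ccccc2)cc1)C(N)=O` gives 55 mg/kg

Compound 1 stands lowest of the three numbers. The nearest is compound 3, reached by a 2.3-fold higher number from compound 1 to compound 3 (0.36 log units; beyond the scatter); the furthest is compound 2, reached by a 4.7-fold higher number from compound 1 to compound 2 (0.67 log units; beyond the scatter). Between the two larger amine substituents the step is a 2.0-fold lower number from compound 2 to compound 3 (0.31 log units; beyond the scatter). All three measured steps alter the group on the amine nitrogen and leave the benzyl ether untouched.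

Compound 4 `C[C@@H](NCc1ccc(OCC2CCCCC2)cc1)C(N)=O` is the next one to be measured. Its change from compound 1 is cyclohexyl in place of phenyl on a saturated chain carbon bound to an oxygen on an aromatic ring. Among the compounds with values here, none of the measured steps bears on this part of the molecule, so the measured steps give no direct guidance. Within the data shown here, the only comparison available is that the amine-side changes moved the number within a modest span, and nothing in the data marks the ether-side ring as a strongly sensitive site. The expected step is therefore a 1.1-fold higher number from compound 1 to compound 4 (0.04 log units; within the scatter), with no step beyond the scatter anticipated, but with wide uncertainty in both directions. For compound 4 the estimate in this assay is 26 mg/kg, with a range from 10 mg/kg to 70 mg/kg.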

Compound 4, dose for half-maximal effect: 131 mg/kg
Compound 4: the middle estimate sits 5.0-fold (0.70 log units) below what was measured; the whole stated range lies below it.
By their numbers in this assay, from the lowest: compound 1; then compound 3; then compounds 2 and 4 (each within the scatter of the next).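

In this assay, the ether side of the molecule proves responsive: with cyclohexyl in place of phenyl on a saturated chain carbon bound to an oxygen on an aromatic ring, the step is (a 5.5-fold higher number from compound 1 to compound 4 (0.74 log units; beyond the scatter)). The change swaps an aromatic ring of carbon only for a non-aromatic one, with heavy atom count, hydrogen-bond donors and acceptors and net charge the same on both sides, so among the compounds shown the aromatic phenyl goes with the lower number, on this single pair only. This site is thus no quieter than the group on the amine nitrogen, where the steps include (a 4.7-fold higher number from compound 1 to compound 2 (0.67 log units; beyond the scatter)), although no measurement shown explains the new step.

The compounds shown leave open whether a pyridyl ring, a fluorophenyl group or a longer chain between the oxygen and the ring would keep the number of compound 1, which is 23.8 mg/kg. From the compounds shown here alone, the change is also seen on one background only, so it remains open whether cyclohexyl in place of phenyl gives a step of similar size on the amine substituents of compound 2 and compound 3.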